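This account rests on a few compounds, and the source may have more. Where it says the series, first, only, none or still open, it means among the compounds named here.

Values so far in a physicochemical assay for lipophilicity, read by HPLC, at pH 7.4 (on this read-out higher numbers stand for higher lipophilicity and lower numbers for lower lipophilicity), are:
- compound 1 `CN(C)Cc1csc(NC(=O)c2cc(C(C)(C)C)nn2Cc2ccccc2)n1` gives 4.2
- compound 2 `CC(C)(C)c1cc(C(=O)Nc2ccncc2)n(Cc2ccccc2)n1` gives 4

Compound 2 at 4 stands within the scatter of compound 1, so these two numbers cannot be told apart. Compound 3 `CC(C)(C)c1cc(C(=O)Nc2cccnc2)n(Cc2ccccc2)n1` is still unmeasured and differs from compound 2 in one place. The change is pyridin-3-yl in place of pyridin-4-yl on an amide-type nitrogen and it puts pyridin-3-yl in place of pyridin-4-yl on an amide-type nitrogen.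

Among the compounds with values here, only one measured step bears on this, made on the same amide-type nitrogen, and it is a number 0.20 log units lower from compound 1 to compound 2 (within the scatter) for a larger change of group than the present one. One step is thin evidence, but it points to little movement. The expected step is a number 0.10 log units higher from compound 2 to compound 3 (within the scatter) in this assay and no shift in either direction beyond the scatter is expected. For compound 3 the estimate is 4.1 with an expected range from 3.7 to 4.5 on this measurement.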

Compound 3, distribution coefficient: 3.8
Compound 3: the middle estimate sits 0.30 log units above what was measured; the measured number falls inside the stated range.
By their numbers in this assay, from the lowest: compounds 3, 2 and 1 (each within the scatter of the next, the first and the last beyond it).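

In this assay, pyridin-3-yl in place of pyridin-4-yl on the amide-type nitrogen gives a number 0.20 log units lower from compound 2 to compound 3 (within the scatter), so these two rings, built from the same atoms joined differently, cannot be told apart on this read-out. Within the data shown here, this is the first look at a change that only rearranges the ring, with the group's size and its counted donors and acceptors left the same. Among these compounds, the position is not wholly insensitive to its group, however: pyridin-3-yl in place of 4-((dimethylamino)methyl)-1,3-thiazol-2-yl gives a number 0.40 log units lower from compound 1 to compound 3 (beyond the scatter), the first step here to pass the scatter, though only modestly.

Still open, from the compounds shown here alone, is how pyridin-2-yl, or a phenyl ring carrying a carboxylic acid, would read on this same nitrogen. No measurement at hand gives a reason for either step.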